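Isopropyl for Cyclohexyl on a Shared Amide Carbonyl

A few compounds are considered here, and "the series" means these few. Any claim that something is new, unique, unknown or untested is made for them only; others in the source may bear on it.

Compound 1 `COC(=O)/C=C/c1cccc(N(Cc2ccc(/C=C/c3cc(C(F)(F)F)cc(C(F)(F)F)c3)cc2)C(=O)C2CCCCC2)c1` and compound 2 `COC(=O)/C=C/c1cccc(N(Cc2ccc(/C=C/c3cc(C(F)(F)F)cc(C(F)(F)F)c3)cc2)C(=O)C(C)C)c1` share one core and differ in a single place: isopropyl in place of cyclohexyl on a carbonyl carbon. In an assay on isolated protein with Bile acid receptor (Homo sapiens) as the target (a higher number here means that more compound is needed for the effect, a lower number that less compound is needed), compound 1 gives 1470 nM, and compound 2 gives 1950 nM. The step between them, a 1.3-fold higher number from compound 1 to compound 2 (0.12 log units; within the scatter), is small and within the scatter of repeated measurements, so the two values are best read as alike.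

Compound 3 `COC(=O)/C=C/c1cccc(N(Cc2ccc(/C=C/c3cccc(Cl)c3)cc2)C(=O)C2CCCCC2)c1` carries a different core; the difference between the core of compound 3 and the core of compound 1 is not broken down here. In this assay compound 3 gives 165 nM, the lowest of the three measured numbers, and its distance to both compound 1 and compound 2 lies beyond the scatter.

Compound 4 `COC(=O)/C=C/c1cccc(N(Cc2ccc(/C=C/c3cccc(Cl)c3)cc2)C(=O)C(C)C)c1` has not yet been measured. It stands to compound 3 exactly as compound 2 stands to compound 1: isopropyl in place of cyclohexyl on a carbonyl carbon. The place is worded the same in both cases, so this is the same change, made a second time on the core of compound 3.

Because the earlier change gave only a 1.3-fold higher number from compound 1 to compound 2 (0.12 log units; within the scatter), compound 4 is expected in this assay to give about 215 nM. The expected range for compound 4 runs from 90 nM to 500 nM. The expected step is a 1.3-fold higher number from compound 3 to compound 4 (0.11 log units; within the scatter), a small move that would stay close to the scatter.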

Compound 4, half-maximal effective concentration: 164 nM
Beside the measured number, compound 4's estimate is 1.3-fold (0.12 log units) above it, within the range that was stated.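

In this assay, replacing cyclohexyl with isopropyl on the carbonyl carbon of the core of compound 3 gives a 1.0-fold lower number from compound 3 to compound 4 (0.00 log units; within the scatter), so compound 3 and compound 4 are best read as alike. Set beside the earlier step, the change carries over from one core to the other with no difference that can be told from the scatter: the same change on two cores in this assay, a 1.3-fold higher number (0.12 log units; within the scatter) from compound 1 to compound 2 and a 1.0-fold lower number (0.00 log units; within the scatter) from compound 3 to compound 4, 1.3-fold (0.13 log units) apart, within the scatter of two such steps. Among the compounds shown here, this shows that, for these two pairs, isopropyl and cyclohexyl on the amide carbonyl are interchangeable in this measurement, but with only two cores it does not establish a rule for the rest of the series, and it does not explain why the two groups read alike.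

The compounds shown leave open whether this indifference extends beyond these two groups, since a methyl, a tert-butyl, a phenyl or a longer chain ending in an amine on the same carbonyl carbon might not read the same way. They also leave open whether the same swap would stay as quiet on a core with a carboxylic acid in place of the methyl ester.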